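The source may report more compounds than this note shows. Statements on the series, on what has been measured and on what is new or still open speak of the compounds shown alone.

Compound 1 `CC1CN(C(=O)c2c(N)sc(-c3ccc(Cl)cc3)c2-c2ccc(Cl)cc2)CCN1` gives 7210 nM in a functional assay on PC-3 cells (Homo sapiens) for inhibition, read by sulforhodamine B assay, with a stated time of 72 h (on this read-out lower numbers stand for stronger inhibition and higher numbers for weaker inhibition), the lowest of the three numbers at hand. Compound 2 `CCCCNC(=O)c1c(N)sc(-c2ccc(Cl)cc2)c1-c1ccc(Cl)cc1` gives 17800 nM and compound 3 `Nc1sc(-c2ccc(Cl)cc2)c(-c2ccc(Cl)cc2)c1C(=O)NC1CCCC1` gives 21200 nM; the steps read a 2.5-fold higher number from compound 1 to compound 2 (0.39 log units; beyond the scatter) and a 2.9-fold higher number from compound 1 to compound 3 (0.47 log units; beyond the scatter), while a 1.2-fold higher number from compound 2 to compound 3 (0.08 log units; within the scatter). Compound 4 `Nc1sc(-c2ccc(Cl)cc2)c(-c2ccc(Cl)cc2)c1C(=O)N1CCNCC1` differs from compound 1 by hydrogen in place of methyl on a saturated ring carbon. Going by the values given here, no measured step removes only the methyl from the piperazin-1-yl ring; the two steps from compound 1 exchange the whole 3-methylpiperazin-1-yl for butylamino or cyclopentylamino, each with a modest loss. The ring itself is kept in compound 4, so no step beyond the scatter is expected, a 1.1-fold higher number from compound 1 to compound 4 (0.05 log units; within the scatter). Compound 4 is estimated at 8000 nM, between 4000 nM and 16000 nM.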

Compound 4, half-maximal inhibitory concentration: 2710 nM
The estimate for compound 4 lay 3.0-fold (0.47 log units) above the measured number; the measured number lies below the stated range.
By their numbers in this assay, from the lowest: compound 4; then compound 1; then compounds 2 and 3 (each within the scatter of the next).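

In this assay, hydrogen in place of methyl on a saturated ring carbon gives a 2.7-fold lower number from compound 1 to compound 4 (0.42 log units; beyond the scatter), so the methyl is not required for the lower number and its removal alone improves on compound 1. The unsubstituted piperazin-1-yl also stands further from the open amides than the methylated ring does, with a 6.6-fold lower number from compound 2 to compound 4 (0.82 log units; beyond the scatter) and a 7.8-fold lower number from compound 3 to compound 4 (0.89 log units; beyond the scatter). No evidence is available to explain why removing the methyl lowers the number. Going by these compounds, whether an ethyl group on this ring carbon, or an acetyl group on the ring nitrogen, keeps this gain remains open.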